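The source may hold more compounds than are shown below. What is called first, only, known or untested is meant among the compounds shown, and "the series" means these compounds.

Measured so far:
compound 1, `COc1cccc(Sc2c(NS(=O)(=O)c3ccc(C(C)(C)C)cc3)noc2CCCC#N)c1`, 520 nM
compound 2, `COc1cccc(Sc2c(NS(=O)(=O)c3ccc(C(C)(C)C)cc3)noc2CCCCC=O)c1`, 20 nM
compound 3, `COc1cccc(Sc2c(NS(=O)(=O)c3ccc(C(C)(C)C)cc3)noc2CCC/C=N/O)c1`, 85 nM

In an assay on COS-7 cells for displacement of a labelled ligand from Endothelin receptor type B (Sus scrofa) (a lower number here means a stronger inhibitor, a higher number a weaker inhibitor), compound 3 stands second highest of the three numbers: compound 2 lies nearest, with a 4.3-fold higher number from compound 2 to compound 3 (0.63 log units; beyond the scatter), and compound 1 furthest, with a 6.1-fold lower number from compound 1 to compound 3 (0.79 log units; beyond the scatter). Compound 4, `COc1cccc(Sc2c(NS(=O)(=O)c3ccc(C(C)(C)C)cc3)noc2C)c1`, differs from compound 3 in one place: a hydrogen atom in place of a group of 5 heavy atoms (3 carbon, 1 nitrogen, 1 oxygen; no ring), on a saturated chain carbon bound to an aromatic carbon.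

All three measured steps touch the far end of that same chain and leave the chain itself intact. They show that the end group matters: a 26-fold lower number from compound 1 to compound 2 (1.41 log units; beyond the scatter), a 6.1-fold lower number from compound 1 to compound 3 (0.79 log units; beyond the scatter) and a 4.3-fold higher number from compound 2 to compound 3 (0.63 log units; beyond the scatter). Within the data shown here, no measured step removes the chain, so the change to compound 4 has no direct precedent here. Since the chain end alone moved the numbers this much, taking the whole chain away is expected to weaken binding, with a 9.4-fold higher number from compound 3 to compound 4 (0.97 log units; beyond the scatter). For compound 4 the estimate in this assay is 800 nM, within a range of 150 nM to 4000 nM.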

Compound 4, half-maximal inhibitory concentration: 300 nM
Estimate against measurement, compound 4: 2.7-fold (0.43 log units) above, and the stated range covers the measured number.
By their numbers in this assay, from the lowest: compound 2; then compound 3; then compounds 4 and 1 (each within the scatter of the next).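

In this assay, among these compounds, compound 4 shows for the first time what the chain is worth against no chain at all: losing it costs binding relative to the oxime-ended chain (a 3.5-fold higher number from compound 3 to compound 4 (0.55 log units; beyond the scatter)) and more relative to the aldehyde-ended chain (a 15-fold higher number from compound 2 to compound 4 (1.18 log units; beyond the scatter)). The nitrile-ended chain gives no such gain (a 1.7-fold lower number from compound 1 to compound 4 (0.24 log units; within the scatter)), so in these compounds a chain at this position does not help by itself, and what it carries decides the outcome. Nothing available explains why these end groups differ.

From the compounds shown here alone, how a carboxylic acid, an amine or an alcohol at the chain end would compare remains open. So does whether a nitrile on a longer chain would close the gap to compound 2.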